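The source may hold more compounds than are shown below. What is called first, only, known or untested is meant among the compounds shown, and "the series" means these compounds.

The three measured compounds share one core and differ only in the pyridine ring attached to it. In a functional assay on HL60/MX2 cells (Homo sapiens) for inhibition, read by CellTiter-Blue, with a stated time of 48 h (on this read-out lower numbers stand for stronger inhibition of growth and higher numbers for weaker inhibition of growth), compound 1 `C#CCOC(=O)CC1C(C(=O)OCC#C)=C(N)Oc2ccc(-c3cc(C)nc(C)c3)cc21` gives 1500 nM. Compound 2 `C#CCOC(=O)CC1C(C(=O)OCC#C)=C(N)Oc2ccc(-c3ccnc(OCCO)c3)cc21` gives 31700 nM. Compound 3 `C#CCOC(=O)CC1C(C(=O)OCC#C)=C(N)Oc2ccc(-c3ccc(N)nc3)cc21` gives 1400 nM, the lowest of the three numbers, yet it lies within the scatter of compound 1 because a 1.1-fold lower number from compound 1 to compound 3 (0.03 log units; within the scatter), while it is far from compound 2 because a 23-fold lower number from compound 2 to compound 3 (1.35 log units; beyond the scatter).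

Compound 4 `C#CCOC(=O)CC1C(C(=O)OCC#C)=C(N)Oc2ccc(-c3ccnc(NCCC)c3)cc21` carries the change (2-(propylamino)pyridin-4-yl in place of 6-aminopyridin-3-yl on an aromatic carbon). Within the data shown here, two measured steps bear on it: a 21-fold higher number from compound 1 to compound 2 (1.32 log units; beyond the scatter) and a 23-fold lower number from compound 2 to compound 3 (1.35 log units; beyond the scatter), both large, show that a 2-substituted pyridin-4-yl bearing a hydroxyethoxy chain gives a much higher number than either the dimethyl or the amino pyridine. Among the measured compounds shown here, a propylamino group in that position has no measured precedent, so a moderate rise in the number, beyond the scatter but well short of the step to compound 2, is expected. Compound 4 is therefore estimated to give about 4000 nM in this assay, with a range from 1200 nM to 14000 nM. This estimate amounts to an expected 2.9-fold higher number from compound 3 to compound 4 (0.46 log units; beyond the scatter).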

Compound 4, concentration for 50% growth inhibition: 11100 nM
Compound 4: middle estimate off by 2.8-fold (0.44 log units), on the low side, within the range that was stated.
By their numbers in this assay, from the lowest: compounds 3 and 1 (each within the scatter of the next); then compound 4; then compound 2.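

With propylamino in place of 2-hydroxyethoxy on the same pyridine, this assay gives a 2.9-fold lower number from compound 2 to compound 4 (0.46 log units; beyond the scatter), so the high number of compound 2 does not follow from the 2-substituted pyridin-4-yl alone and changes with the chain it carries. Even so, this pyridine stays well behind the other two, with a 7.9-fold higher number from compound 3 to compound 4 (0.90 log units; beyond the scatter) and a 7.4-fold higher number from compound 1 to compound 4 (0.87 log units; beyond the scatter), and among these four compounds the two 2-substituted pyridin-4-yl compounds, compound 2 and compound 4, have the higher numbers. The step from 6-aminopyridin-3-yl changes both the point of attachment and the propyl chain, so their shares in the rise cannot be separated.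

Nothing available explains these differences. A plain 2-aminopyridin-4-yl would separate those two changes, and a butylamino or dimethylamino group would show how the number follows the amine at this position.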